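This account rests on a few compounds, and the source may have more. Where it says the series, first, only, none or still open, it means among the compounds named here.

In a functional assay on NCI-H460 cells (Homo sapiens) for antiproliferative activity, read by CCK-8 assay, with a stated time of 72 h, tested at 2 uM (a lower number here means a weaker effect, a higher number a stronger effect of the compound at the concentration tested), three compounds built on one shared core have been tested. Compound 1 `Nc1ccccc1NC(=O)c1ccc(Cn2cnc3c(Nc4ccccc4)nc(Cl)nc32)cc1` gives 42.7% in this assay. Compound 2 `Nc1ccccc1NC(=O)c1ccc(Cn2cnc3c(NCc4ccccc4)nc(Cl)nc32)cc1` gives 44.7%, and compound 3 `Nc1ccccc1NC(=O)c1ccc(CNc2nc(Cl)nc3c2ncn3Cc2ccccc2)cc1` gives 43.8%. Compound 2 holds the highest of the three numbers, yet compound 1 and compound 3 both sit within the scatter of it, so none of the three can be called stronger than the others. For the measured compounds named here, the only single-point step among them, a number 2 percentage points higher from compound 1 to compound 2 (within the scatter), is within the scatter as well.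

Compound 4 `Nc1ccccc1NC(=O)c1ccc(Cn2cnc3c(Nc4cccc(Cl)c4)nc(Cl)nc32)cc1` differs from compound 2 by 3-chlorophenyl in place of benzyl on a nitrogen on an aromatic ring. The step that bears on this change is a number 2 percentage points higher from compound 1 to compound 2 (within the scatter), which swapped phenyl for benzyl on the same nitrogen and moved the number only within the scatter. Going back to a phenyl ring, now carrying a chlorine, is therefore expected to give no step beyond the scatter, a number 1.7 percentage points lower from compound 2 to compound 4 (within the scatter). For compound 4 the expected value in this assay is 43%, with a range from 30% to 56%.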

Compound 4, a percentage reported as inhibition, at one concentration (the size of the read-out at that concentration, not a potency): 10.3%
For compound 4 the middle estimate is 32.7 percentage points above the measured one; measured number below the stated range.
By their numbers in this assay, from the lowest: compound 4; then compounds 1, 3 and 2 (each within the scatter of the next).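

Until now this nitrogen on an aromatic ring seemed to accept change freely, since phenyl and benzyl there gave numbers within the scatter of each other, but the new result shows that it does not accept every group. In this assay 3-chlorophenyl in place of benzyl gives a number 34.4 percentage points lower from compound 2 to compound 4 (beyond the scatter) and the smaller change of chloro in place of hydrogen on an aromatic carbon gives a number 32.4 percentage points lower from compound 1 to compound 4 (beyond the scatter) with nothing else altered. The loss therefore goes with the added chlorine and not with the return from benzyl to a phenyl ring, as compound 1 and compound 2 remain within the scatter of each other.

Going by these compounds, whether a fluorine, a methyl or a methoxy group on that phenyl ring would bring a similar loss remains open. Nothing shown here gives a reason for the loss.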